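Benzyl change on the shared core: stability notes

The source may report more compounds than this note shows. Statements on the series, on what has been measured and on what is new or still open speak of the compounds shown alone.

Measured in an in vitro ADME assay on microsomes from liver (Homo sapiens) for metabolic stability, tested at 1 uM; on this read-out lower numbers stand for a shorter-lived compound and higher numbers for a longer-lived compound:
- compound 1 `COc1cccc(CN2C(=O)C(C3=NS(=O)(=O)c4cc(NS(C)(=O)=O)ccc4N3)=C(O)[C@@H]3[C@H]4CC[C@H](C4)[C@@H]32)c1`: > 1 h
- compound 2 `CS(=O)(=O)Nc1ccc2c(c1)S(=O)(=O)N=C(C1=C(O)[C@@H]3[C@@H]4CC[C@@H](C4)[C@@H]3N(Cc3ccccc3)C1=O)N2`: > 1 h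
- compound 3 `CS(=O)(=O)Nc1ccc2c(c1)S(=O)(=O)N=C(C1=C(O)[C@@H]3[C@@H]4CC[C@@H](C4)[C@@H]3N(Cc3ccccc3F)C1=O)N2`: > 1 h

Compound 3 stands at > 1 h as a limit and not a number. Compound 4 `COc1cccc(CN2C(=O)C(C3=NS(=O)(=O)c4cc(NS(C)(=O)=O)ccc4N3)=C(O)[C@@H]3[C@@H]4CC[C@@H](C4)[C@@H]32)c1` carries 3-methoxyphenyl in place of 2-fluorophenyl on a saturated chain carbon bound to an amide-type nitrogen in a ring, as counted in 3-methoxyphenyl in place of 2-fluorophenyl on a saturated chain carbon bound to an amide-type nitrogen in a ring here. Among the compounds with values here, the only measured step is a step that the two limits leave unreadable from compound 2 to compound 3 and offers no size to carry over. The record so far is the limit of > 1 h in this assay, at which 3 of the 3 values shown sit, and shows no movement in either direction. The expected change is a step that the limit leaves unreadable from compound 3 to compound 4 with no direction anticipated in this assay and nothing expected beyond the scatter. Compound 4 is estimated at 1.5 h with a range of 0.7 h to 3 h and is expected to return only a limit.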

Compound 4, half-life: > 1 h
Compound 4: no number, only a limit; the forecaster's own chance of this, stated with the estimate: 85%; the middle value is on the limit's open side.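

No step can be read between compound 4 and compound 1, compound 2 or compound 3 in this assay: the limit of > 1 h in this assay, at which 4 of the 4 values shown sit.

As far as these compounds go, the actual half-lives stay open, as does whether the benzyl changes or the configuration difference between compound 1 and compound 4 shift them at all.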